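Chalcone series: adding methoxy beside the phenol of compound 1

The source may report more compounds than this note shows. Statements on the series, on what has been measured and on what is new or still open speak of the compounds shown alone.

Measured compounds:
compound 1 `COc1cc(OC)c(C(=O)/C=C/c2ccc(O)cc2)c(OC)c1`, 49400 nM
compound 2 `COc1cc(OC)c(C(=O)/C=C/c2ccccc2OC)c(OC)c1`, 19800 nM
compound 3 `COc1cc(OC)c(C(=O)/C=C/c2ccc(C)cc2)c(OC)c1`, 15000 nM

Compound 1 `COc1cc(OC)c(C(=O)/C=C/c2ccc(O)cc2)c(OC)c1` carries a 4-hydroxyphenyl group on its double-bonded chain carbon; in a functional assay on A549 cells (Homo sapiens) for inhibition, read by MTT assay, with a stated time of 72 h (on this read-out higher numbers stand for weaker inhibition and lower numbers for stronger inhibition), compound 1 gives 49400 nM, the highest of the three numbers shown. Compound 2 `COc1cc(OC)c(C(=O)/C=C/c2ccccc2OC)c(OC)c1` in this assay gives 19800 nM, and compound 3 `COc1cc(OC)c(C(=O)/C=C/c2ccc(C)cc2)c(OC)c1` gives 15000 nM; between these two the step of a 1.3-fold lower number from compound 2 to compound 3 (0.12 log units; within the scatter) lies within the scatter.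

Compound 4 `COc1cc(OC)c(C(=O)/C=C/c2ccc(O)c(OC)c2)c(OC)c1` is the unmeasured compound. It differs from compound 1 by methoxy in place of hydrogen on an aromatic carbon, on an aromatic carbon ortho to a hydroxy group and meta to a large group. Among the measured compounds shown here, no measured step adds a group while keeping the hydroxy in place. For the measured compounds named here, the steps that bear on it only loosely are a 2.5-fold lower number from compound 1 to compound 2 (0.40 log units; beyond the scatter) and a 3.3-fold lower number from compound 1 to compound 3 (0.52 log units; beyond the scatter), both modest lowerings when the 4-hydroxyphenyl group is altered. Since the hydroxy group of compound 1 is retained in compound 4, a smaller step is expected, a 1.4-fold lower number from compound 1 to compound 4 (0.15 log units; within the scatter), at or near the edge of the scatter. Compound 4 is therefore estimated at 35000 nM in this assay, within a range of 12000 nM to 100000 nM.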

Compound 4, half-maximal inhibitory concentration: 43800 nM
Beside the measured number, compound 4's estimate is 1.3-fold (0.10 log units) below it, within the range that was stated.
By their numbers in this assay, from the lowest: compounds 3 and 2 (each within the scatter of the next); then compounds 4 and 1 (each within the scatter of the next).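

In this assay, methoxy in place of hydrogen on an aromatic carbon, ortho to a hydroxy group and meta to a large group, gives a 1.1-fold lower number from compound 1 to compound 4 (0.05 log units; within the scatter), a step within the scatter. The earlier steps shown here from compound 1 all replaced the 4-hydroxyphenyl group as a whole, whereas this one shows that adding methoxy at this position with the hydroxy group kept has no effect that can be told from the scatter in this read-out. Nothing available here explains this result.

The compounds shown leave open whether an amine, a fluorine atom or a longer alkoxy chain at this same position would also stay within the scatter of compound 1. They also leave open whether methoxy at this position would give a similar step on a core without the hydroxy group.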